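This account rests on a few compounds, and the source may have more. Where it says the series, first, only, none or still open, it means among the compounds named here.

Compound 3 `Cc1ccc(OCC(=O)N(Cc2cccs2)c2ncco2)cc1` stands at the lowest number of the three measured compounds in an assay on HEK293 cells for agonist activity at transient receptor potential cation channel subfamily M member 8 (Homo sapiens), read by fluorescence and calcium flux, with a stated time of 15 min (a lower number here means that less compound is needed, a higher number that more compound is needed for the effect), giving 0.3 nM. Its nearest neighbour is compound 2 `Cc1ccc(OCC(=O)N(Cc2cccs2)C2CC2)cc1`, which gives 8 nM, and the furthest is compound 1 `Cc1ccc(OCC(=O)N(Cc2cccs2)c2ccnn2C)cc1`, which gives 422 nM. The measured steps are a 27-fold lower number from compound 2 to compound 3 (1.43 log units; beyond the scatter), a 1400-fold lower number from compound 1 to compound 3 (3.15 log units; beyond the scatter) and a 53-fold lower number from compound 1 to compound 2 (1.72 log units; beyond the scatter), so every change at the amide-type nitrogen so far has moved the number by a large amount.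

Compound 4 `CCC(C)N(Cc1cccs1)C(=O)COc1ccc(C)cc1` differs from compound 3 in one place: sec-butyl in place of 1,3-oxazol-2-yl on an amide-type nitrogen. The step that bears most directly on this is a 27-fold lower number from compound 2 to compound 3 (1.43 log units; beyond the scatter), since cyclopropyl, like sec-butyl, is not an aromatic ring, and replacing it with 1,3-oxazol-2-yl lowered the number by a large amount. Going the other way, from 1,3-oxazol-2-yl to sec-butyl, is therefore expected to raise the number in this assay by a similar large amount, though sec-butyl is not cyclopropyl and no measured pair shows how these two groups compare. The expected step is a 33-fold higher number from compound 3 to compound 4 (1.52 log units; beyond the scatter). Compound 4 is accordingly estimated at 10 nM in this assay, with a range from 2 nM to 60 nM.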

Compound 4, half-maximal effective concentration: 2000 nM
Compound 4: middle estimate off by 200-fold (2.30 log units), on the low side, and the stated range ends below it.
By their numbers in this assay, from the lowest: compound 3; then compound 2; then compound 1; then compound 4.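

In this assay, the step of a 250-fold higher number from compound 2 to compound 4 (2.40 log units; beyond the scatter) shows that two groups without an aromatic ring on the amide-type nitrogen need not give similar numbers, so cyclopropyl proved a poor guide to sec-butyl at this position. The exchange of 1,3-oxazol-2-yl for sec-butyl, a 6700-fold higher number from compound 3 to compound 4 (3.82 log units; beyond the scatter), is the widest step at this position among the four compounds. The groups also do not sort by the presence of an aromatic ring: with a 4.7-fold higher number from compound 1 to compound 4 (0.68 log units; beyond the scatter), sec-butyl lies closer to 1-methyl-1H-pyrazol-5-yl than to cyclopropyl, and compound 2, with its non-aromatic cyclopropyl, falls between the two aromatic compounds, compound 3 and compound 1.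

The compounds shown leave open where a cyclobutyl group, a straight propyl chain or a 2-pyridyl ring on the amide-type nitrogen would fall, and so whether the gap between cyclopropyl and sec-butyl follows from the ring, the chain branching or something else. They also leave open whether 1,3-oxazol-2-yl would keep its place if the rest of the shared core were changed. Nothing given here accounts for the size of these steps.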